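A Free Hydroxyl in Place of the Methoxy Group

This account rests on a few compounds, and the source may have more. Where it says the series, first, only, none or still open, it means among the compounds named here.

Measured compounds:
compound 1 `COc1cc(Cl)cc(-c2nn(-c3cccc(NC(=O)Nc4ccc(Cl)c(C(F)(F)F)c4)c3)cc2-c2ccncc2)c1` gives -94% in a functional assay on HCT-116 cells (Homo sapiens) for inhibition, read by sulforhodamine B assay, with a stated time of 48 h, tested at 100 uM; a lower number here means a stronger effect, a higher number a weaker effect of the compound at the concentration tested;
compound 2 `COc1cc(Cl)cc(-c2nn(-c3cccc(NC(=O)c4cccc(C(F)(F)F)c4)c3)cc2-c2ccncc2)c1` gives 22% in this assay;
compound 3 `O=C(Nc1cccc(-n2cc(-c3ccncc3)c(-c3cc(O)cc(Cl)c3)n2)c1)c1cc(C(F)(F)F)cc(C(F)(F)F)c1` gives 5% in this assay.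

Compound 1 stands lowest of the three numbers in this assay, with compound 3 the nearest and compound 2 the furthest from it. For the measured compounds named here, the only step between two compounds that differ in one place is a number 116 percentage points higher from compound 1 to compound 2 (beyond the scatter), where 3-(trifluoromethyl)phenyl replaces (4-chloro-3-(trifluoromethyl)phenyl)amino on a carbonyl carbon, and it is large.

Compound 4 `O=C(Nc1cccc(-n2cc(-c3ccncc3)c(-c3cc(O)cc(Cl)c3)n2)c1)Nc1ccc(Cl)c(C(F)(F)F)c1` has not yet been measured. It differs from compound 1 as follows: hydrogen in place of methyl on an oxygen on an aromatic ring. Going by the values given here, no measured step isolates this change: compound 3 carries the hydroxy, but it also carries a different group on the carbonyl carbon than compound 1, so its value and that of compound 1 cannot be read as a step of one change. The large step from compound 1 to compound 2 concerns a different part of the molecule and does not bear on it.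

With nothing that speaks against the change, compound 4 is expected to stay close to compound 1, with a step of a number 19 percentage points higher from compound 1 to compound 4 (beyond the scatter) that may lie within the scatter. The estimate for compound 4 is -75%, in the range from -100% to -20%.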

Compound 4, a percentage reported as activity, at one concentration (the size of the read-out at that concentration, not a potency): -57%
Compound 4: middle estimate off by 18 percentage points, on the low side; low and high end bracket the measured number.
By their numbers in this assay, from the lowest: compound 1; then compound 4; then compound 3; then compound 2.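

The change from methoxy to hydroxy on the 3-chloro-5-methoxyphenyl group can now be read on its own: in this assay the step is a number 37 percentage points higher from compound 1 to compound 4 (beyond the scatter), so this position on the aromatic ring is not indifferent to the loss of the methyl on the oxygen. The step is large, yet it leaves the read-out on the same side of zero, with compound 4 at -57%, so the hydroxy form keeps a negative number of the kind seen for compound 1. Nothing available gives a cause for the size or direction of this step.

As far as these compounds go, the change has been read only with the (4-chloro-3-(trifluoromethyl)phenyl)amino group on the carbonyl carbon, so whether it has the same size with the other groups on that carbonyl remains open, since compound 2 and compound 3 differ in more than one place. From the compounds shown here alone, it is also open what an amine or a longer chain such as ethoxy would give on the oxygen-bearing position of this ring, and therefore whether the read-out follows any order across such groups.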